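Adding ethyl to an amide at the assay limit

The source may report more compounds than this note shows. Statements on the series, on what has been measured and on what is new or still open speak of the compounds shown alone.

In an ADME assay on HeLa cells (Homo sapiens) for cytotoxicity, read by crystal violet staining, with a stated time of 72 h (a lower number here means that less compound is tolerated, a higher number that more compound is tolerated), compound 1 `CCOC(=O)c1cc(CCCOc2c(C)cc(-c3noc(C(F)(F)F)n3)cc2C)on1`, which carries ethoxycarbonyl, gives 17200 nM. Compound 2 `Cc1cc(-c2noc(C(F)(F)F)n2)cc(C)c1OCCCc1cc(-c2ccc(OC(F)(F)F)cc2)no1` reads > 100000 nM, which is a limit of the assay and not a number. Compound 3 `Cc1cc(-c2noc(C(F)(F)F)n2)cc(C)c1OCCCc1cc(C(N)=O)no1`, which carries carbamoyl, reads > 100000 nM, again only a limit. Compound 3 therefore stands at the limit of > 100000 nM in this assay, at which 2 of the 3 values shown sit.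

Compound 4 `CCNC(=O)c1cc(CCCOc2c(C)cc(-c3noc(C(F)(F)F)n3)cc2C)on1` differs from compound 3 by ethyl in place of hydrogen on an amide-type nitrogen, turning carbamoyl into ethylcarbamoyl.

For the measured compounds named here, no measured step makes this exact change. The closest is an at least 5.8-fold higher number from compound 1 to compound 3 (0.76 log units; beyond the scatter), with amino in place of ethoxy on a carbonyl carbon. The step of an at least 5.8-fold higher number from compound 1 to compound 2 (0.76 log units; beyond the scatter) changes the same group for 4-(trifluoromethoxy)phenyl, while a step that the two limits leave unreadable from compound 2 to compound 3 gives no size. Compound 4 regains an ethyl, as in the ethoxy of compound 1 at 17200 nM, so part of the way back towards that value is expected. The expected change is an at least 1.4-fold lower number from compound 3 to compound 4 (0.15 log units; that floor lies within the scatter), a modest move towards a lower number, though the reading may again be only a limit. For compound 4 the estimate is 70000 nM, with an expected range from 25000 nM to 140000 nM.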

Compound 4, half-maximal cytotoxic concentration: > 100000 nM
Compound 4 ended at the assay's limit; the forecaster's own chance of this, stated with the estimate: 50%; middle value at least 1.4-fold (0.15 log units) from the limit.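

In this assay, ethyl on the amide-type nitrogen does not bring the series back to a measurable reading: compound 4, which carries ethylcarbamoyl, reads > 100000 nM, which is a limit of the assay and not a number. The ethyl alone therefore does not restore the reading of the ester, and with the ethyl kept, ethylamino in place of ethoxy on a carbonyl carbon gives an at least 5.8-fold higher number from compound 1 to compound 4 (0.76 log units; beyond the scatter), so that ethoxycarbonyl remains the only group shown at this position with a number rather than a limit. The steps from compound 3 to compound 4 and from compound 2 to compound 4 cannot be read, both ends being limits, and the series now stands as follows: the limit of > 100000 nM in this assay, at which 3 of the 4 values shown sit.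

Going by these compounds, how far past the limit compound 2, compound 3 and compound 4 lie stays open, so no order among them can be given. Also open, on these data alone, is whether a carboxylic acid at this position, or a longer chain such as butyl on the amide-type nitrogen, would give a number rather than a limit.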